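Trimming One Methyl from the Sulfonyl Chain

The source may report more compounds than this note shows. Statements on the series, on what has been measured and on what is new or still open speak of the compounds shown alone.

Compound 1 `CC(C)S(=O)(=O)N(Cc1ccccc1-c1ccccc1)[C@H]1CCNC1` was tested in an in vitro ADME assay on microsomes from liver (Homo sapiens) for metabolic stability (on this read-out lower numbers stand for slow clearance and higher numbers for fast clearance), where compound 1 gives 20 mL.min-1.g-1. Of the two values shown for this set, compound 1 holds the only one that is an actual number. Compound 2 `CC(C)C(=O)N(Cc1ccccc1C(C)C)[C@H]1CCNC1` gives in this assay a result that is a limit of the assay rather than a number, < 7 mL.min-1.g-1. That limit is the point at which one of the two values sits (the limit of < 7 mL.min-1.g-1 in this assay, at which 1 of the 2 values shown sits). Compound 3 `CCS(=O)(=O)N(Cc1ccccc1-c1ccccc1)[C@H]1CCNC1` has not yet been measured. It differs from compound 1 in one place only: hydrogen in place of methyl on a saturated chain carbon bound to a saturated chain carbon and a sulfonyl sulfur. The rest of the structure, including the shared core, is the same in both. Within the data shown here, no pair of measured compounds here differs by a single change, so there is no measured step to lean on for this one. The loss of one methyl is a small change, and the step of a 1.3-fold lower number from compound 1 to compound 3 (0.12 log units; within the scatter) is expected to stay within the usual scatter, with a slight lean toward slower clearance. Compound 3 is therefore expected to give about 15 mL.min-1.g-1 in this assay, with a likely range from 7 mL.min-1.g-1 to 35 mL.min-1.g-1.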

Compound 3, intrinsic clearance in microsomes: < 7 mL.min-1.g-1
Compound 3 ended at the assay's limit; the forecaster's own chance of this, stated with the estimate: 20%; at least 2.1-fold (0.33 log units) between middle value and limit.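

Going from isopropylsulfonyl to ethylsulfonyl gives the first comparison in this set in which only one place changes, and in this assay it reads as an at least 2.8-fold lower number from compound 1 to compound 3 (0.45 log units; beyond the scatter). This shows that the position, a saturated chain carbon bound to a saturated chain carbon and a sulfonyl sulfur, matters for this read-out: removing one methyl there moves the result beyond the usual scatter, toward slower clearance. Compound 3 gives < 7 mL.min-1.g-1, which is a limit of the assay and not a number, so the step has only a minimum size and its full size stays unknown: the limit of < 7 mL.min-1.g-1 in this assay, at which 2 of the 3 values shown sit.

The compounds shown leave open whether clearance follows the length of the sulfonyl chain, which a methylsulfonyl group or a longer chain such as propylsulfonyl on the same core could help to show. They also leave open whether the same change would have a similar result on a different core, and compound 2 cannot settle this, as it differs from compound 3 in more than one place.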